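A few compounds are considered here, and "the series" means these few. Any claim that something is new, unique, unknown or untested is made for them only; others in the source may bear on it.

Measured compounds:
Compound 1 `COc1cccc(-n2cc(COc3c(/C=C\C(=O)O)ccc(OC)c3CC=C(C)C)nn2)c1`: 23200 nM
Compound 2 `COc1ccc(/C=C\C(=O)O)c(OCc2cn(-c3cccc([N+](=O)[O-])c3)nn2)c1CC=C(C)C`: 18400 nM

In a functional assay on A-431 cells (Homo sapiens) for cytotoxicity, read by MTT assay, with a stated time of 24 h (on this read-out lower numbers stand for stronger inhibition and higher numbers for weaker inhibition), compound 2 gives 18400 nM, and this number sits alongside compound 1, since the step of a 1.3-fold lower number from compound 1 to compound 2 (0.10 log units; within the scatter) stays within the scatter. Compound 3 `COc1ccc(/C=C\C(=O)O)c(OCc2cn(-c3ccccc3C#N)nn2)c1CC=C(C)C` differs from compound 2 by 2-cyanophenyl in place of 3-nitrophenyl on an aromatic nitrogen. Among the measured compounds shown here, the only step measured so far, a 1.3-fold lower number from compound 1 to compound 2 (0.10 log units; within the scatter), also swapped a group on the same phenyl ring and changed little, so in this assay a change no larger than the scatter is expected, with the estimated step of a 1.1-fold higher number from compound 2 to compound 3 (0.04 log units; within the scatter). Compound 3 is therefore estimated at 20000 nM, within 8000 nM to 50000 nM.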

Compound 3, half-maximal inhibitory concentration: 10300 nM
Compound 3: the middle estimate sits 1.9-fold (0.29 log units) above what was measured; low and high end bracket the measured number.
By their numbers in this assay, from the lowest: compounds 3, 2 and 1 (each within the scatter of the next, the first and the last beyond it).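

In this assay, among the compounds shown here, changing the group on the aromatic nitrogen now gives a first step beyond the scatter: 2-cyanophenyl in place of 3-methoxyphenyl gives a 2.3-fold lower number from compound 1 to compound 3 (0.35 log units; beyond the scatter). Against 3-nitrophenyl, the same group gives only a 1.8-fold lower number from compound 2 to compound 3 (0.25 log units; within the scatter), so the separation is modest and holds against just one of the two earlier groups. Nothing measured here gives a reason for this. On these data alone, whether the nitrile itself or its place on the ring matters remains open, as does how 3-cyanophenyl or an aminophenyl group would compare.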